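Exchanging the Charged Head at the Chain End

The source may report more compounds than this note shows. Statements on the series, on what has been measured and on what is new or still open speak of the compounds shown alone.

Compound 3 `CCCCCCCCCCCCCCC1COC(COCCCCCCC[n+]2ccsc2)C1` gives 830 nM in a functional assay (Oryctolagus cuniculus) for inhibition of platelet-activating factor receptor (Cavia porcellus) (a lower number here means a stronger inhibitor, a higher number a weaker inhibitor), the lowest of the three numbers: compound 2 `CCCCCCCCCCCCCCC1COC(COCCCCCC[N+](C)(C)C)C1` gives 8200 nM and compound 1 `CCCCCCCCCCCCCCC1COC(COCCCC[n+]2ccsc2)C1` gives 39000 nM. The steps ran as a 9.9-fold lower number from compound 2 to compound 3 (0.99 log units; beyond the scatter) and a 47-fold lower number from compound 1 to compound 3 (1.67 log units; beyond the scatter), while a 4.8-fold lower number from compound 1 to compound 2 (0.68 log units; beyond the scatter). Compound 4 `CCCCCCCCCCCCCCC1COC(COCCCCCC[N+]2(C)C=CN=C2)C1` is not yet measured; it differs from compound 3 by a group of 6 heavy atoms (4 carbon, 2 nitrogen; one five-membered non-aromatic ring with 2 hetero atoms) in place of a group of 6 heavy atoms (4 carbon, 1 nitrogen, 1 sulfur; one five-membered aromatic ring with 2 hetero atoms), on a saturated chain carbon, six bonds along the chain from an oxygen on a saturated carbon. For the measured compounds named here, only one measured step bears on a head-group exchange at this place, namely a 9.9-fold lower number from compound 2 to compound 3 (0.99 log units; beyond the scatter), and it was modest; the other steps also altered the chain. A small step is therefore expected, a 1.8-fold higher number from compound 3 to compound 4 (0.26 log units; within the scatter), and no large move in either direction. Compound 4 is estimated at 1500 nM in this assay, in the range 400 nM to 6000 nM.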

Compound 4, half-maximal inhibitory concentration: 6000 nM
For compound 4 the middle estimate is 4.0-fold (0.60 log units) below the measured one; measured number inside the range.
By their numbers in this assay, from the lowest: compound 3; then compounds 4 and 2 (each within the scatter of the next); then compound 1.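

In this assay, the five-membered non-aromatic ring with 2 hetero atoms does not match the five-membered aromatic ring with 2 hetero atoms at this place, with a 7.2-fold higher number from compound 3 to compound 4 (0.86 log units; beyond the scatter). Carrying a ring here is therefore not enough: a 1.4-fold lower number from compound 2 to compound 4 (0.14 log units; within the scatter), and a 6.5-fold lower number from compound 1 to compound 4 (0.81 log units; beyond the scatter), a step that also alters the chain. Nothing measured here accounts for these differences.

As far as these compounds go, whether compound 3 owes its standing to the sulfur-bearing ring or to its chain stays open. A pyridinium head, or a longer chain carrying either ring, would help separate the two.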